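The source may hold more compounds than are shown below. What is called first, only, known or untested is meant among the compounds shown, and "the series" means these compounds.

Compounds measured so far:
- compound 1 `CC(C)(C)Cc1csc(N)c1C(=O)c1ccc(Cl)cc1`: 1%
- compound 2 `CC(C)(C)Cc1c(-c2ccc(F)cc2)sc(N)c1C(=O)c1ccc(Cl)cc1`: 1%
- compound 3 `CC(C)(C)Cc1c(/C=C/c2ccc(Cl)cc2)sc(N)c1C(=O)c1ccc(Cl)cc1`: 1%

In an assay on CHO cells for displacement of a labelled ligand from adenosine receptor A1 (Homo sapiens), read by scintillation counting, tested at 10 uM (on this read-out lower numbers stand for less inhibition and higher numbers for more inhibition at the one concentration tested (going by the name of the read-out)), compound 3 gives 1%. On the numbers shown it stands level with the other two compounds: the step of no change at the digits printed from compound 1 to compound 3 (within the scatter) and the step of no change at the digits printed from compound 2 to compound 3 (within the scatter) are both within the scatter, so nothing separates these three compounds on this read-out.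

Compound 4 `CC(C)c1ccc(-c2sc(N)c(C(=O)c3ccc(Cl)cc3)c2CC(C)(C)C)cc1` is the next compound to be measured. Its difference from compound 3 is this: 4-isopropylphenyl in place of 2-(4-chlorophenyl)ethenyl on an aromatic carbon. Among the measured compounds shown here, the steps that bear on this change are those in which the same aromatic carbon carried a different group: no change at the digits printed from compound 1 to compound 2 (within the scatter), no change at the digits printed from compound 1 to compound 3 (within the scatter) and no change at the digits printed from compound 2 to compound 3 (within the scatter). None of them moved the read-out beyond the scatter, whether that carbon carried hydrogen, 4-fluorophenyl or 2-(4-chlorophenyl)ethenyl. A fourth group at that carbon is therefore expected to behave the same way, and the step of a number 1 percentage points higher from compound 3 to compound 4 (within the scatter) is estimated to stay within the scatter, with no direction. Compound 4 is thus expected to give 2%, in the range -7% to 11%.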

Compound 4, a percentage reported as inhibition, at one concentration (the size of the read-out at that concentration, not a potency): 1%
Estimate against measurement, compound 4: 1 percentage points above; low and high end bracket the measured number.
By their numbers in this assay, from the lowest: compounds 1, 2, 3 and 4 (each within the scatter of the next).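

In this assay the aromatic carbon next to the ring sulfur takes 4-isopropylphenyl in place of 2-(4-chlorophenyl)ethenyl with no change at the digits printed from compound 3 to compound 4 (within the scatter) and so a group made of carbon alone, without the chlorine or the double bond, reads the same as the earlier one. Isopropyl in place of fluoro on the phenyl ring gives no change at the digits printed from compound 2 to compound 4 (within the scatter) and 4-isopropylphenyl in place of hydrogen gives no change at the digits printed from compound 1 to compound 4 (within the scatter) and so neither the group on that phenyl ring nor the ring itself separates these compounds. No measurement here explains why the read-out stays flat.

Going by these compounds, it remains open whether an aminomethyl group or a carboxylic acid on this carbon would shift the read-out. On these data alone, it is also open whether replacing the neopentyl group with a different chain, or changing the (4-chlorophenyl)carbonyl group, would do so.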